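The source may report more compounds than this note shows. Statements on the series, on what has been measured and on what is new or still open speak of the compounds shown alone.

In a toxicity assay on NIH3T3 cells (Mus musculus) for cytotoxicity, read by resazurin assay (on this read-out higher numbers stand for an effect only at larger amounts of compound and lower numbers for an effect already at smaller amounts), compound 1, `c1ccc(-c2ccc(Cn3cncc3CNc3ccc(-c4ccc[nH]4)c(-c4ccccc4)c3)cc2)cc1`, gives > 10000 nM, which is a limit of the assay rather than a number. That value sits at the limit of > 10000 nM in this assay, at which 1 of the 3 values shown sits. Compound 2, `COC(=O)c1ccc(NCc2cncn2Cc2ccc(OC)cc2)cc1-c1ccccc1`, has "not determined" (no result reported) in this assay, so no result was reported for it. Compound 3, `O=[N+]([O-])c1ccc(Cn2cncc2CNc2cccc(-c3ccccc3)c2)cc1`, gives 10000 nM in this assay. Compound 4, `CC(=O)c1ccc(NCc2cncn2Cc2ccc(-c3ccccc3)cc2)cc1-c1ccccc1`, has not yet been measured in this assay. Its structure differs from compound 1 in one place: acetyl in place of 1H-pyrrol-2-yl on an aromatic carbon. The exchange sits on an aromatic carbon of a six-membered aromatic ring of carbon only, ortho to a phenyl group and para to a large group. Among the measured compounds shown here, no step between two measured compounds is known here, so nothing shows how much such a change moves this read-out. Compound 1 stands at the limit and compound 3 stands at a number close to it. The step of a number no higher from compound 1 to compound 4 (the limit leaves the size open) is expected to stay within the usual scatter, in no clear direction. For compound 4 the expected value in this assay is 10000 nM, within a range from 3000 nM to 30000 nM.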

Compound 4, half-maximal effective concentration: > 10000 nM
Compound 4 was reported as a limit (the forecaster's own chance of this, stated with the estimate: 50%); the middle value sits exactly at the limit.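

Compound 1 and compound 4 both end at a limit of the assay rather than at a number, so the step between them cannot be read: the limit of > 10000 nM in this assay, at which 2 of the 4 values shown sit.

The compounds shown leave open how far acetyl in place of 1H-pyrrol-2-yl moves the result in this assay.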